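Swapping Bromo for Trifluoromethyl on Two Inactive Analogues

This account rests on a few compounds, and the source may have more. Where it says the series, first, only, none or still open, it means among the compounds named here.

Compound 1 `C=C1C[C@]23C[C@@]1(O)CC[C@H]2c1ccc(OS(=O)(=O)c2ccc(C)cc2)c(C)c1[C@@H]3Cn1cc(-c2ccc(C)cc2)nn1` gives > 20000 nM, a limit of the assay rather than a number. Compound 2 `C=C1C[C@]23C[C@@]1(O)CC[C@@H]2c1cccc(C)c1[C@@H]3Cn1cc(-c2ccc(Br)cc2)nn1` gives > 20000 nM, again a limit rather than a number.

Both figures come from a functional assay on SMMC-7721 cells (Homo sapiens) for cytotoxicity, read by MTT assay, with a stated time of 4 days; a lower number here means a stronger inhibitor, a higher number a weaker inhibitor. Compound 2 therefore stands at the edge of what this measurement can report: it has no number of its own, only (the limit of > 20000 nM in this assay, at which 2 of the 2 values shown sit). Compound 1 tells the same story, so neither measured compound shows any cytotoxicity that this assay can quantify.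

Compound 3 `C=C1C[C@]23C[C@@]1(O)CC[C@@H]2c1cccc(C)c1[C@@H]3Cn1cc(-c2ccc(C(F)(F)F)cc2)nn1` is built from compound 2 by a single change, (trifluoromethyl in place of bromo on an aromatic carbon). Within the data shown here, no measured pair shows the effect of this change, so nothing in the data points to either direction. Given that compound 2 sits at > 20000 nM and that compound 1, with a different change, also reaches only a limit, the expected step from compound 2 to compound 3 is none beyond the scatter, written as a step that the limit leaves unreadable from compound 2 to compound 3. Compound 3 is expected to give about 30000 nM, between 10000 nM and 100000 nM, most likely reported once more as a limit.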

Compound 3, half-maximal inhibitory concentration: > 20000 nM
Compound 3: a limit, no number (the forecaster's own chance of this, stated with the estimate: 80%); the middle value is on the limit's open side.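

In this assay compound 3 gives > 20000 nM, again a limit and not a number. Among these compounds, compound 2 has only a limit as well, so no step between compound 2 and compound 3 can be read. The compounds shown leave open whether trifluoromethyl in place of bromo changes cytotoxicity at all, and what change to the shared core would give a readable number.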